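Compound 4 and the Half-Life Limit

The source may hold more compounds than are shown below. What is called first, only, known or untested is meant among the compounds shown, and "the series" means these compounds.

Compound 3 (`O=C(NCc1cccs1)N1C(=O)c2ccccc2S1(=O)=O`) gives only a limit in a physicochemical assay for pharmacokinetics (on this read-out higher numbers stand for a longer-lived compound and lower numbers for a shorter-lived compound), > 166 h. Compound 1 (`O=C(NCc1ccccc1Br)N1C(=O)c2ccccc2S1(=O)=O`) also gives only a limit, > 166 h. Compound 2 (`Cc1ccccc1CNC(=O)N1C(=O)c2ccccc2S1(=O)=O`) likewise gives only a limit, > 166 h. The three compounds share one ceiling: the limit of > 166 h in this assay, at which 3 of the 3 values shown sit. Compound 4 (`COc1ccccc1CNC(=O)N1C(=O)c2ccccc2S1(=O)=O`) carries 2-methoxyphenyl in place of thiophen-2-yl on a saturated chain carbon bound to an amide-type nitrogen. For the measured compounds named here, three measured steps bear on this change: a step that the two limits leave unreadable from compound 1 to compound 2, a step that the two limits leave unreadable from compound 1 to compound 3 and a step that the two limits leave unreadable from compound 2 to compound 3. None has a readable size, so they point in no direction, and no step beyond the scatter is expected in this assay. The estimated step is a step that the limit leaves unreadable from compound 3 to compound 4. Compound 4 is expected at 200 h, with an estimated range of 100 h to 400 h.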

Compound 4, half-life: > 166 h
Compound 4 ended at the assay's limit; the forecaster's own chance of this, stated with the estimate: 85%; the middle value lies beyond the limit too.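

Compound 4 gives > 166 h as a limit and not a number, so no new step can be read between it and compound 1, compound 2 or compound 3, which share one ceiling: the limit of > 166 h in this assay, at which 4 of the 4 values shown sit.

The compounds shown leave open how long each one really lasts in this assay and whether these changes of group alter that at all.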